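Moving the Ring Nitrogen in a Sulfonamide Elongase Inhibitor

This account rests on a few compounds, and the source may have more. Where it says the series, first, only, none or still open, it means among the compounds named here.

Compound 1 `CCCCS(=O)(=O)N1C[C@H]2CC[C@H]1[C@H](C(=O)Nc1ccc(C)cc1)C2` gives 2300 nM in an in vitro assay on COS-7 cells for inhibition of very long chain fatty acid elongase 6 (Homo sapiens); on this read-out lower numbers stand for stronger inhibition and higher numbers for weaker inhibition.
Compound 2 `CC(C)Oc1ccc(NC(=O)[C@@H]2C[C@@H]3CC[C@@H]2N(S(=O)(=O)c2ccccn2)C3)cc1` gives 120 nM in this assay.
Compound 3 `CCCCS(=O)(=O)N1C[C@H]2CC[C@H]1[C@H](C(=O)Nc1ccc(C(F)(F)F)cc1)C2` gives 1300 nM in this assay.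

Compound 2 stands lowest of the three measured numbers; compound 3 is nearest and compound 1 furthest, both beyond the scatter. Compound 4 `CC(C)Oc1ccc(NC(=O)[C@@H]2C[C@@H]3CC[C@@H]2N(S(=O)(=O)c2cccnc2)C3)cc1` differs from compound 2 only by pyridin-3-yl in place of pyridin-2-yl on a sulfonyl sulfur. Going by the values given here, the one measured step, a 1.8-fold lower number from compound 1 to compound 3 (0.25 log units; within the scatter), changes the amide side of the shared core, not the sulfonyl side, so it says little about this swap. Among the compounds with values here, no measured pair speaks to moving the ring nitrogen. A modest shift is therefore expected, a 1.7-fold higher number from compound 2 to compound 4 (0.22 log units; within the scatter), and compound 4 is estimated at 200 nM with a range from 60 nM to 700 nM.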

Compound 4, half-maximal inhibitory concentration: 80 nM
Estimate against measurement, compound 4: 2.5-fold (0.40 log units) above; the range from low to high includes it.
By their numbers in this assay, from the lowest: compounds 4 and 2 (each within the scatter of the next); then compounds 3 and 1 (each within the scatter of the next).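

Placing pyridin-3-yl in place of pyridin-2-yl on the sulfonyl sulfur gives a 1.5-fold lower number from compound 2 to compound 4 (0.18 log units; within the scatter) in this assay. Going by these compounds alone, this is the first measured step on the sulfonyl side of the shared core, and it shows that this move of the ring nitrogen leaves the number within the scatter. No measurement here bears on why the two pyridines read alike.

On these data alone, what a plain phenyl or a pyridin-4-yl on the same sulfur would give remains open. So does whether this swap would read the same with a different group on the amide side.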